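Working notes: side-chain removal on the shared core

The compounds below may be only part of what the source reports. "The series", "measured", "known", "first", "only" and "open" are said of these compounds alone.

Two compounds of the series carry a measured value. Compound 1 `C=CCOc1ccc2c(NCCCN(C)C)ccnc2c1` and compound 2 `CCOc1ccc2c(NCCCN(C)C)ccnc2c1` share one core and differ only at the ether end; in a functional assay on HCT-116 cells (Homo sapiens) for cytotoxicity, read by MTT assay, with a stated time of 48 h (a higher number here means a weaker inhibitor, a lower number a stronger inhibitor), compound 1 gives 2100 nM and compound 2 gives 3380 nM. Among the measured compounds shown here, the only measured step is a 1.6-fold higher number from compound 1 to compound 2 (0.21 log units; within the scatter), so compound 1 holds the lowest of the two numbers, though its gap to compound 2 lies within the scatter and no order between them can be claimed.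

Compound 3 `C=CCOc1ccc2c(Cl)ccnc2c1` is not yet measured. It differs from compound 1 by chloro in place of (3-(dimethylamino)propyl)amino on an aromatic carbon. For the measured compounds named here, no measured step touches this part of the core: the step from compound 1 to compound 2 concerns only the ether substituent and says nothing about exchanging the (3-(dimethylamino)propyl)amino group for chloro. The expectation therefore rests on the structural change alone, and a larger step than anything measured is expected, toward a weaker inhibitor, expressed as a 7.1-fold higher number from compound 1 to compound 3 (0.85 log units; beyond the scatter). For compound 3 the estimated value in this assay is 15000 nM, expected to fall between 4000 nM and 60000 nM.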

Compound 3, half-maximal inhibitory concentration: 2570 nM
Estimate against measurement, compound 3: 5.8-fold (0.77 log units) above; measured number below the stated range.
By their numbers in this assay, from the lowest: compounds 1, 3 and 2 (each within the scatter of the next).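

In this assay, chloro in place of (3-(dimethylamino)propyl)amino, on the aromatic carbon opposite the ring nitrogen, gives a 1.2-fold higher number from compound 1 to compound 3 (0.09 log units; within the scatter), so the two groups cannot be told apart at this position in this read-out. The earlier pair spoke only to the ether end; this step shows that the whole (3-(dimethylamino)propyl)amino group, with its hydrogen-bond donor and acceptors and its basic-named dimethylamino end, can leave this carbon without a difference beyond the scatter. No supporting measurement is available to account for this result.

Open, on these data alone, is how a longer amine chain, a piperazine or a plain hydrogen on this aromatic carbon would read in this assay, and whether any of them would stand beyond the scatter from compound 1. Also open, as far as these compounds go, is whether the same exchange for chloro would read the same way with the ether end of compound 2, since the present step holds only for the ether end of compound 1.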